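Chlorine in Place of Fluorine on the Anilide Ring

The compounds below may be only part of what the source reports. "The series", "measured", "known", "first", "only" and "open" are said of these compounds alone.

Of the compounds shown here, two sharing one core have been measured so far. Compound 1 `CC1=C(C(=O)Nc2ccc(F)c(Cl)c2)C(c2cccc(O)c2)NC(=S)N1` gives 25100 nM in a functional assay on PC-3 cells (Homo sapiens) for cytotoxicity, read by sulforhodamine B assay, with a stated time of 48 h; a lower number here means a stronger inhibitor of growth, a higher number a weaker inhibitor of growth. Compound 2 `CC1=C(C(=O)Nc2ccc(F)c(Cl)c2)C(c2cccc(Oc3ccccc3)c2)NC(=O)N1` gives 22400 nM in this assay. The two numbers lie within the usual scatter of each other, so the data do not separate them; both compounds are weak inhibitors of growth in this cell line.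

Compound 3 `CC1=C(C(=O)Nc2ccc(Cl)c(Cl)c2)C(c2cccc(O)c2)NC(=S)N1` is not yet measured. It differs from compound 1 in one place: chloro in place of fluoro on an aromatic carbon. Within the data shown here, no measured pair shows the effect of this swap, so there is nothing to lean on beyond the structural change itself. The change is small, and the expected step of a 1.3-fold lower number from compound 1 to compound 3 (0.10 log units; within the scatter) is none beyond the scatter. Compound 3 is therefore estimated at 20000 nM in this assay, with a range from 8000 nM to 50000 nM.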

Compound 3, concentration for 50% growth inhibition: 14100 nM
Beside the measured number, compound 3's estimate is 1.4-fold (0.15 log units) above it, and the stated range covers the measured number.
By their numbers in this assay, from the lowest: compounds 3, 2 and 1 (each within the scatter of the next).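

Among these compounds, compound 1 and compound 3 form the first measured pair for chloro in place of fluoro on an aromatic carbon, the change from 3-chloro-4-fluorophenyl to 3,4-dichlorophenyl. In this assay this swap gives a 1.8-fold lower number from compound 1 to compound 3 (0.25 log units; within the scatter) and so, at this position para to a large group, the data do not separate the two halogens. No measurement at hand explains the size of this step or says what the swap does beyond this single number.

From the compounds shown here alone, whether a different group at this position, such as an amine, a methoxy group or a carboxylic acid, would give a step beyond the scatter remains open. Also open, going by these compounds, is whether the same swap would give a similar step on compound 2, which carries different groups elsewhere on the shared core.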